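A few compounds are considered here, and "the series" means these few. Any claim that something is new, unique, unknown or untested is made for them only; others in the source may bear on it.

Three compounds share one core and were read in the same way. Compound 1 `Nc1ccccc1NC(=O)c1ccc(CSC(=S)N2CCN(Cc3ccccn3)CC2)cc1` gives 14.2% in a functional assay on HeLa cells (Homo sapiens) for antiproliferative activity, read by CCK-8 assay, with a stated time of 72 h, tested at 2 uM; on this read-out lower numbers stand for a weaker effect and higher numbers for a stronger effect at the one concentration tested. Compound 2 `Nc1ccccc1NC(=O)c1ccc(CSC(=S)N2CCN(C(c3ccccc3)c3ccccc3)CC2)cc1` gives 8%. Compound 3 `CN(C(=S)SCc1ccc(C(=O)Nc2ccccc2N)cc1)c1cccnc1` gives 16%, the highest of the three numbers, though its gaps to compound 1 and to compound 2 both lie within the usual scatter. The unmeasured compound 4 `CN(Cc1ccncc1)C(=S)SCc1ccc(C(=O)Nc2ccccc2N)cc1` differs from compound 3 in one place: (pyridin-4-yl)methyl in place of pyridin-3-yl on an amide-type nitrogen. Going by the values given here, because compound 3 sits at 16% and no measured pair separates beyond the scatter, no step beyond the scatter is expected here. The expected step is a number 2 percentage points lower from compound 3 to compound 4 (within the scatter) in this assay. Compound 4 is estimated at 14%, within a range from 4% to 26%.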

Compound 4, a percentage reported as inhibition, at one concentration (the size of the read-out at that concentration, not a potency): 29.5%
Beside the measured number, compound 4's estimate is 15.5 percentage points below it; the measured number lies above the stated range.
By their numbers in this assay, from the lowest: compounds 2, 1 and 3 (each within the scatter of the next); then compound 4.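

On the amide-type nitrogen, (pyridin-4-yl)methyl in place of pyridin-3-yl gives a number 13.5 percentage points higher from compound 3 to compound 4 (beyond the scatter) in this assay. Going by these compounds alone, this is the first change to stand clear of the scatter, so this position responds to what it carries in a way the earlier compounds could not show. Nothing available explains the step. The compounds shown leave open whether the added carbon or the shift from pyridin-3-yl to pyridin-4-yl carries it, as (pyridin-3-yl)methyl and pyridin-4-yl would tell. Going by these compounds, how benzyl or 2-(pyridin-4-yl)ethyl would read there also stays open.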